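The source may hold more compounds than are shown below. What is called first, only, known or untested is meant among the compounds shown, and "the series" means these compounds.

Of the compounds shown here, three have been measured so far in a functional assay on PC-3 cells (Homo sapiens) for inhibition, read by sulforhodamine B assay; on this read-out higher numbers stand for weaker inhibition of growth and lower numbers for stronger inhibition of growth. Compound 1 (`COc1ccc(-c2ccc(-c3ccc(-c4nc5cc(C)ccc5[nH]4)cc3)cc2)cc1OC`) gives 2560 nM, compound 2 (`COc1cc(-c2ccc(-c3ccc(-c4nc5ccccc5[nH]4)cc3)cc2)cc(OC)c1OC`) gives 9720 nM, and compound 3 (`Oc1cccc2[nH]c(-c3ccc(-c4ccc(-c5ccccc5)cc4)cc3)nc12`) gives 1240 nM. Compound 3 has the lowest number of the three, which makes it the strongest growth inhibitor in this small set, and its gaps to the other two lie beyond the usual scatter of repeat measurements.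

The next compound, compound 4 (`CN(C)c1ccc(-c2ccc(-c3ccc(-c4nc5c(O)cccc5[nH]4)cc3)cc2)cc1`), keeps the structure of compound 3 except in one place, where phenyl becomes 4-(dimethylamino)phenyl: dimethylamino in place of hydrogen on an aromatic carbon. Among the compounds with values here, no two measured compounds differ in only one place, so there is no direct precedent for this change. The only hint is indirect. Compound 1 at 2560 nM and compound 2 at 9720 nM both carry methoxy groups on that phenyl and both give higher numbers than compound 3, yet they also differ from it elsewhere. On this slim evidence, a modest step towards weaker inhibition is expected, although a step within the scatter would be no surprise. The expected change is a 1.8-fold higher number from compound 3 to compound 4 (0.25 log units; within the scatter), which is only a rough estimate. For compound 4 the estimated value is 2200 nM, with an expected range from 700 nM to 7000 nM.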

Compound 4, concentration for 50% growth inhibition: 8420 nM
The estimate for compound 4 lay 3.8-fold (0.58 log units) below the measured number; the whole stated range lies below it.
By their numbers in this assay, from the lowest: compound 3; then compound 1; then compounds 4 and 2 (each within the scatter of the next).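

Within the data shown here, this is the first comparison in the set in which only one place changes, so it gives a direct reading of this position. In this assay, placing dimethylamino on an aromatic carbon in place of hydrogen, para to a large group, gives a 6.8-fold higher number from compound 3 to compound 4 (0.83 log units; beyond the scatter), a step beyond the scatter towards weaker inhibition of growth. The position therefore responds to substitution, and for this one change the unsubstituted phenyl is the better of the two, although no measurement shown here accounts for the loss.

A single group at a single place cannot show whether any substituent here would weaken inhibition or whether the effect is specific to dimethylamino, and a small group such as methyl or fluorine, or a larger one such as a carboxylic acid, could behave quite differently. Going by these compounds, it also remains open whether dimethylamino would produce a step of similar size at another place on this ring or on a shared core carrying different groups elsewhere.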